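Swapping an aromatic ring for cyclohexyl on the thiourea

The compounds below may be only part of what the source reports. "The series", "measured", "known", "first", "only" and "open" are said of these compounds alone.

Compound 1, `Cc1cccc(NC(=S)N/N=C/c2cccc3ccccc23)c1`: 450 nM
Compound 2, `COc1cccc(NC(=S)N/N=C/c2cccc3ccccc23)c1`: 830 nM
Compound 3, `Cc1ccccc1NC(=S)N/N=C/c1cccc2ccccc12`: 490 nM

All three compounds share a core and differ only in the group attached to an amide-type nitrogen. In a functional assay on B16 cells (Mus musculus), read by spectrophotometry, with a stated time of 3 days (a higher number here means a weaker inhibitor, a lower number a stronger inhibitor), compound 3 gives 490 nM, and on the numbers shown it is separated from neither of the other two beyond the scatter: a 1.1-fold higher number from compound 1 to compound 3 (0.04 log units; within the scatter) and a 1.7-fold lower number from compound 2 to compound 3 (0.23 log units; within the scatter), with the remaining pair likewise close, a 1.8-fold higher number from compound 1 to compound 2 (0.27 log units; within the scatter).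

Compound 4, `S=C(N/N=C/c1cccc2ccccc12)NC1CCCCC1`, differs from compound 3 by cyclohexyl in place of 2-methylphenyl on an amide-type nitrogen. Going by the values given here, none of the measured steps bears directly on this change: each of them exchanges one substituted aromatic ring for another, whereas here the aromatic ring itself leaves and a saturated ring enters. Those three steps were all small, which hints that this nitrogen accepts varied groups, but the present change is of a different kind, so the expected step of a 1.6-fold higher number from compound 3 to compound 4 (0.21 log units; within the scatter) is given with wide uncertainty. Compound 4 is estimated in this assay at 800 nM, with a range from 300 nM to 2500 nM.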

Compound 4, half-maximal inhibitory concentration: 290 nM
Estimate against measurement, compound 4: 2.8-fold (0.44 log units) above; measured number outside the range, below it.
By their numbers in this assay, from the lowest: compounds 4, 1, 3 and 2 (each within the scatter of the next, the first and the last beyond it).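

In this assay, the aromatic ring on this amide-type nitrogen can give way to cyclohexyl, a non-aromatic ring of carbon only, with a 1.7-fold lower number from compound 3 to compound 4 (0.23 log units; within the scatter) and a 1.6-fold lower number from compound 1 to compound 4 (0.19 log units; within the scatter), so neither replacement of a methylphenyl group separates from the scatter. Replacing 3-methoxyphenyl gives a 2.9-fold lower number from compound 2 to compound 4 (0.46 log units; beyond the scatter), a modest step and the only one of the three to pass beyond the scatter, so an aromatic ring at this position is not required for a number in this range. Nothing available explains why the saturated ring serves as well as the aromatic ones.

Going by these compounds, whether this nitrogen also accepts a smaller ring such as cyclopentyl, a straight butyl chain or a group carrying an amine or a carboxylic acid remains open. The compounds shown also leave open whether cyclohexyl would behave the same way on a different core.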